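The source may report more compounds than this note shows. Statements on the series, on what has been measured and on what is new or still open speak of the compounds shown alone.

Compound 2, `O=[N+]([O-])c1cc(C(F)(F)F)cc([N+](=O)[O-])c1Oc1ccccc1/C=N\OCc1ccccc1F`, gave 680 nM in a functional assay on HepG2 cells (Homo sapiens) for antiproliferative activity, read by MTT assay, with a stated time of 48 h; on this read-out higher numbers stand for weaker inhibition and lower numbers for stronger inhibition. Within the data shown here, the only other compound measured there is compound 1, `O=[N+]([O-])c1cc(C(F)(F)F)cc([N+](=O)[O-])c1Oc1ccccc1/C=N\OCc1ccccc1`, which gave 1330 nM in this assay; the two numbers lie within the usual scatter of each other, so no order can be read between them. Among the measured compounds shown here, the single measured step, a 2.0-fold lower number from compound 1 to compound 2 (0.29 log units; within the scatter), separates them.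

Compound 3, `O=[N+]([O-])c1cc(C(F)(F)F)cc([N+](=O)[O-])c1Oc1ccc(Cl)cc1/C=N\OCc1ccccc1F`, has not yet been measured. It differs from compound 2 by chloro in place of hydrogen on an aromatic carbon. For the measured compounds named here, no measured step concerns a chloro group or this ring, so the one available step, which was within the scatter, bears on it only as a reminder that a single halogen on an aromatic carbon has so far moved the number little.

On that basis the author expects the step from compound 2 to compound 3 to be a 1.2-fold lower number from compound 2 to compound 3 (0.09 log units; within the scatter), that is, no change beyond the scatter, with a slight lean toward a lower number. The estimate for compound 3 in this assay is therefore 550 nM, with a range from 220 nM to 1400 nM.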

Compound 3, half-maximal inhibitory concentration: 1020 nM
Beside the measured number, compound 3's estimate is 1.9-fold (0.27 log units) below it, within the range that was stated.
By their numbers in this assay, from the lowest: compounds 2, 3 and 1 (each within the scatter of the next).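

In this assay, chloro in place of hydrogen on an aromatic carbon, meta to a large group and para to a large group, gives a 1.5-fold higher number from compound 2 to compound 3 (0.18 log units; within the scatter) and so shows that this place on a six-membered aromatic ring of carbon only, which the earlier step did not touch, can carry a chloro group with no difference that stands out from the scatter. Read with a 2.0-fold lower number from compound 1 to compound 2 (0.29 log units; within the scatter) for the fluoro replacement made elsewhere in the molecule, it gives two single halogen replacements in two places, neither beyond the scatter, so neither place has yet been shown to affect the number in this assay. No measurement is available that could explain either step.

Going by these compounds, whether a methoxy group, an amine or a carboxylic acid on this same aromatic carbon would give a step beyond the scatter remains open. Also open, on these data alone, is whether chloro on this carbon would give a similar step from compound 1, which has hydrogen where compound 2 has its fluoro group.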